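A few compounds are considered here, and "the series" means these few. Any claim that something is new, unique, unknown or untested is made for them only; others in the source may bear on it.

Compound 1 `COc1cccc(/C=C/C(=O)Nc2cc(OC)c(OC)c(OC)c2)c1` gives 23400 nM
Compound 2 `C=C(Br)C(=O)Nc1cccc(/C=C/C(=O)Nc2ccccc2)c1` gives 190 nM
Compound 3 `C=C(Br)C(=O)Nc1cccc(/C=C/C(=O)Nc2ccc(F)cc2)c1` gives 16600 nM

In a functional assay on CCRF-CEM cells (Homo sapiens) for inhibition, read by MTT assay, with a stated time of 72 h (on this read-out lower numbers stand for stronger inhibition and higher numbers for weaker inhibition), compound 3 gives 16600 nM as its value. That lies within the usual scatter of compound 1 and far above compound 2, meaning much weaker inhibition than compound 2 shows.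

Compound 4 `C=C(Br)C(=O)Nc1cccc(/C=C/C(=O)Nc2ccc(F)c(F)c2)c1` differs from compound 3 by one further swap fluoro in place of hydrogen on an aromatic carbon that turns the 4-fluorophenyl into 3,4-difluorophenyl. For the measured compounds named here, only one measured step is of the same kind, fluoro in place of hydrogen on an aromatic carbon: an 87-fold higher number from compound 2 to compound 3 (1.94 log units; beyond the scatter) is large and beyond the scatter. It shows that such a swap can matter a great deal in this series. However, that step created the 4-fluorophenyl group, whereas this one adds a second fluoro, and a single pair does not set a direction. No step beyond the scatter is therefore expected, though with wide uncertainty. This estimate means a 1.4-fold lower number from compound 3 to compound 4 (0.14 log units; within the scatter) as the expected step. Expected for compound 4 is 12000 nM within a range from 2000 nM to 45000 nM by this estimate.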

Compound 4, half-maximal inhibitory concentration: 13 nM
Estimate against measurement, compound 4: 920-fold (2.97 log units) above; the measured number lies below the stated range.
By their numbers in this assay, from the lowest: compound 4; then compound 2; then compounds 3 and 1 (each within the scatter of the next).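

In this assay, the change from 4-fluorophenyl to 3,4-difluorophenyl gives a 1300-fold lower number from compound 3 to compound 4 (3.11 log units; beyond the scatter) and so runs the opposite way to an 87-fold higher number from compound 2 to compound 3 (1.94 log units; beyond the scatter) on the same ring. Fluoro in place of hydrogen on this ring therefore has no single direction across these three compounds: the lone fluoro of the 4-fluorophenyl group and the added fluoro ortho to it move the number in opposite ways. The pair of fluoro groups also does more than undo the earlier loss, with a 15-fold lower number from compound 2 to compound 4 (1.16 log units; beyond the scatter) against the plain phenyl ring.

On these data alone, whether a chloro, a methyl or a nitrile in place of either fluoro would keep the number this low stays open, as does whether the added fluoro would have the same effect without the first one. Nothing measured here explains how a single added atom can move the number this far.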